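Step from compound 3 to compound 4 on the amide nitrogen

The source may hold more compounds than are shown below. What is called first, only, known or untested is meant among the compounds shown, and "the series" means these compounds.

Three compounds with the shared core have numbers in an assay on isolated protein for inhibition of phosphodiesterase 4A (Sus scrofa); a lower number here means a stronger inhibitor, a higher number a weaker inhibitor. Compound 1 `COc1ccc(C(=O)Nc2ccccc2Cl)cc1OC1CCCC1` gives 190 nM. Compound 2 `COc1ccc(C(=O)Nc2ccccc2O)cc1OC1CCCC1` gives 1300 nM. Compound 3 `COc1ccc(C(=O)NN2C(Cl)=NC=CC2Cl)cc1OC1CCCC1` gives 400 nM. The step of a 6.8-fold higher number from compound 1 to compound 2 (0.84 log units; beyond the scatter) is the largest seen; the step of a 2.1-fold higher number from compound 1 to compound 3 (0.32 log units; beyond the scatter) is smaller, and the step of a 3.3-fold lower number from compound 2 to compound 3 (0.51 log units; beyond the scatter) runs the other way. Compound 3 thus stands second highest of the three, nearest to compound 1 and furthest from compound 2.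

Compound 4 `COc1ccc(C(=O)Nc2c(C)nsc2Br)cc1OC1CCCC1` has not yet been measured. It differs from compound 3 by a group of 7 heavy atoms (4 carbon, 1 nitrogen, 1 sulfur, 1 bromine; one five-membered aromatic ring with 2 hetero atoms) in place of a group of 8 heavy atoms (4 carbon, 2 nitrogen, 2 chlorine; one six-membered non-aromatic ring with 2 hetero atoms), on an amide-type nitrogen. Going by the values given here, the steps that bear on this are those on the same nitrogen: the step of a 2.1-fold higher number from compound 1 to compound 3 (0.32 log units; beyond the scatter) shows that an aromatic halogen-bearing ring on that nitrogen gave the lower number, and the step of a 3.3-fold lower number from compound 2 to compound 3 (0.51 log units; beyond the scatter) shows that a hydroxy-bearing aromatic ring gave a higher one. The entering group is aromatic and carries a halogen, as in compound 1, so in this assay a step of modest size toward a lower number is expected, possibly within the scatter, given as a 1.6-fold lower number from compound 3 to compound 4 (0.20 log units; within the scatter). Compound 4 is therefore estimated at 250 nM, with a range from 80 nM to 800 nM.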

Compound 4, half-maximal inhibitory concentration: 500 nM
For compound 4 the middle estimate is 2.0-fold (0.30 log units) below the measured one, and the stated range covers the measured number.
By their numbers in this assay, from the lowest: compound 1; then compounds 3 and 4 (each within the scatter of the next); then compound 2.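

In this assay, the 5-bromo-3-methyl-1,2-thiazol-4-yl group on the amide-type nitrogen cannot be told apart from the non-aromatic dichlorinated ring of compound 3 (a 1.3-fold higher number from compound 3 to compound 4 (0.10 log units; within the scatter)), so a change of this size in ring type, ring size and halogen leaves the number within the scatter. Having an aromatic ring with a halogen on this nitrogen is therefore not enough to match the 2-chlorophenyl group, as the step from that group to the new one shows (a 2.6-fold higher number from compound 1 to compound 4 (0.42 log units; beyond the scatter)), although the new group still compares well with 2-hydroxyphenyl (a 2.6-fold lower number from compound 2 to compound 4 (0.41 log units; beyond the scatter)). No measurement shown here accounts for any of these differences.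

The compounds shown leave open how much of the gap to compound 1 belongs to the five-membered ring itself and how much to its bromine or methyl, as these groups enter together. Also open, going by these compounds, is how an unsubstituted phenyl ring on the same nitrogen, or a phenyl ring carrying an amine or a methoxy group in place of the chlorine of compound 1, would read in this assay.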